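Sulfanyl substituents on the core of compound 1 in mice

The source may report more compounds than this note shows. Statements on the series, on what has been measured and on what is new or still open speak of the compounds shown alone.

Compound 1 `O=C(CCCN1CCC(n2cnc3ccccc32)CC1)c1ccc(F)cc1` is the parent of this small set. In a functional assay on the whole organism (strain STD-ddY) for inhibition, with Mus musculus as the target, with a stated time of 5 min (on this read-out higher numbers stand for an effect only at larger amounts of compound and lower numbers for an effect already at smaller amounts), compound 1 gives 4.7 mg/kg. Compound 2 `CSc1nc2ccccc2n1C1CCN(CCCC(=O)c2ccc(F)cc2)CC1` gives 6.2 mg/kg and compound 3 `O=C(CCCN1CCC(n2c(SCC(=O)c3ccc(Cl)cc3)nc3ccccc32)CC1)c1ccc(F)cc1` gives 5 mg/kg; the three numbers all lie within the scatter of one another, so none of the three can be set apart from the others.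

The step to compound 4 `O=C(CCCN1CCC(n2c(SCc3ccccc3)nc3ccccc32)CC1)c1ccc(F)cc1` is benzylsulfanyl in place of hydrogen on an aromatic carbon. For the measured compounds named here, two measured steps bear on it, since both put a sulfanyl group at the same aromatic carbon: a 1.3-fold higher number from compound 1 to compound 2 (0.12 log units; within the scatter) with methylsulfanyl, and a 1.1-fold higher number from compound 1 to compound 3 (0.03 log units; within the scatter) with the larger (((4-chlorophenyl)carbonyl)methyl)sulfanyl. The step of a 1.2-fold lower number from compound 2 to compound 3 (0.09 log units; within the scatter) shows that enlarging the group on the sulfur from methyl to a carbonyl-bearing chain also made no difference beyond the scatter. Benzylsulfanyl sits in size between those two groups and carries one six-membered aromatic ring, as the group in compound 3 does.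

No step beyond the scatter is therefore expected in this assay; the estimate is a 1.1-fold higher number from compound 1 to compound 4 (0.04 log units; within the scatter). For compound 4 the expected value in this assay is 5.2 mg/kg, with a range from 2.6 mg/kg to 10.5 mg/kg. A limit rather than a number is not expected, given the numbers found for compounds 1, 2 and 3.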

Compound 4, dose for half-maximal effect: 1.3 mg/kg
For compound 4 the middle estimate is 4.0-fold (0.60 log units) above the measured one; measured number below the stated range.
By their numbers in this assay, from the lowest: compound 4; then compounds 1, 3 and 2 (each within the scatter of the next).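

For the compounds shown here, on the aromatic carbon between two ring nitrogen atoms, benzylsulfanyl gives the first step beyond the scatter in this assay, with a 3.6-fold lower number from compound 1 to compound 4 (0.56 log units; beyond the scatter). The position therefore does respond to a change, but a sulfanyl group alone does not produce the response: methylsulfanyl and (((4-chlorophenyl)carbonyl)methyl)sulfanyl both stayed within the scatter of hydrogen, whereas phenyl on the saturated chain carbon bound to the sulfur gives a 4.8-fold lower number from compound 2 to compound 4 (0.68 log units; beyond the scatter). One six-membered aromatic ring on the sulfur-linked chain is not enough either, since phenyl in place of (4-chlorophenyl)carbonyl gives a 3.8-fold lower number from compound 3 to compound 4 (0.59 log units; beyond the scatter), so the outcome depends on what is attached to that chain carbon. Nothing available here accounts for this difference.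

The compounds shown leave open whether the sulfur itself matters, as benzylamino or benzyloxy at this carbon would test. They also leave open whether a longer chain, as in 2-phenylethylsulfanyl, or a chlorine or a carboxylic acid on the phenyl ring of benzylsulfanyl would keep the lower number.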